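The source may report more compounds than this note shows. Statements on the series, on what has been measured and on what is new or still open speak of the compounds shown alone.

Measured so far:
- Compound 1 `Cc1cc2[nH]nc(N)c2c(=O)[nH]1`: 27%
- Compound 2 `Nc1n[nH]c2cc(-c3cccs3)[nH]c(=O)c12`: 59%

In an assay on isolated protein for inhibition of serine/threonine-protein kinase Chk2 (Homo sapiens), read by mobility shift assay, tested at 30 uM (on this read-out higher numbers stand for more inhibition at the one concentration tested (going by the name of the read-out) and lower numbers for less inhibition), compound 1 gives 27%, the lowest of the two numbers; compound 2 gives 59%. Going by the values given here, the one measured step, a number 32 percentage points higher from compound 1 to compound 2 (beyond the scatter), is a thiophen-2-yl in place of methyl on an aromatic carbon, and is the only change on record for this core.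

Compound 3 `Cc1cc2c(c(N)nn2C)c(=O)[nH]1` differs from compound 1 by methyl in place of hydrogen on an aromatic nitrogen. Among the compounds with values here, this change sits on an aromatic nitrogen, not on the aromatic carbon altered in the step from compound 1 to compound 2, so that step does not bear on it, and no measured step tells how much a methyl on the ring nitrogen counts. The estimate therefore starts from compound 1, with a wide range. Compound 3 is expected to show a downward step, a number 15 percentage points lower from compound 1 to compound 3 (beyond the scatter), in this assay. The value of compound 3 is estimated at 12%, between 0% and 35%.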

Compound 3, a percentage reported as inhibition, at one concentration (the size of the read-out at that concentration, not a potency): 3%
Compound 3: middle estimate off by 9 percentage points, on the high side; measured number inside the range.
By their numbers in this assay, from the lowest: compound 3; then compound 1; then compound 2.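

Methyl in place of hydrogen on the aromatic nitrogen of the five-membered ring lowers inhibition in this assay, with a number 24 percentage points lower from compound 1 to compound 3 (beyond the scatter). Going by these compounds alone, the earlier step concerned only an aromatic carbon, so this is the first sign that a change at this ring nitrogen also matters, even when it adds a single carbon. No supporting data bear on this loss, so these numbers cannot separate the part played by the departing hydrogen from that of the entering methyl.

From the compounds shown here alone, it remains open whether an ethyl group or a longer chain on this nitrogen would give a similar result. Going by these compounds, it also remains open whether the same methyl would have a similar effect on the core carrying thiophen-2-yl, as in compound 2.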